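Tert-butyl on the sulfonamide aniline: the next step

A few compounds are considered here, and "the series" means these few. Any claim that something is new, unique, unknown or untested is made for them only; others in the source may bear on it.

Of the compounds shown here, two have been measured in an assay on isolated protein for inhibition of Nicotinamide phosphoribosyltransferase (Homo sapiens), read by WST assay, with stated times of 60 min, 5 min and 30 min, in the presence of a further agent that is not named here; on this read-out higher numbers stand for weaker inhibition and lower numbers for stronger inhibition. Compound 1 `O=C(/C=C/c1cccnc1)NCCCCc1ccc(S(=O)(=O)Nc2ccccc2)cc1` gives 17.8 nM. Compound 2 `O=C(/C=C/c1cccnc1)NCCCCCCc1cccc(S(=O)(=O)Nc2ccccc2)c1` gives 10.5 nM; the gap to compound 1 lies within the scatter, so the two values do not set either compound apart. For the measured compounds named here, compound 1 and compound 2 differ in more than one place, and no single step between them can be read from the pair.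

Compound 3 `CC(C)(C)c1ccc(NS(=O)(=O)c2cccc(CCCCCCNC(=O)/C=C/c3cccnc3)c2)cc1` is the next compound for this assay. It differs from compound 2 by tert-butyl in place of hydrogen on an aromatic carbon. Going by the values given here, no measured pair carries this change, so its size cannot be taken from the data; the expectation is a step that stays within or near the scatter, with no clear direction. Compound 3 is expected at 8 nM, with a range from 3 nM to 25 nM. The estimated step of a 1.3-fold lower number from compound 2 to compound 3 (0.12 log units; within the scatter) is an expectation only, not a measurement.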

Compound 3, half-maximal inhibitory concentration: 9.47 nM
The estimate for compound 3 lay 1.2-fold (0.07 log units) below the measured number; the measured number falls inside the stated range.
By their numbers in this assay, from the lowest: compounds 3, 2 and 1 (each within the scatter of the next).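

Anilino to (4-(tert-butyl)phenyl)amino, tert-butyl in place of hydrogen on an aromatic carbon, para to a large group, gives a 1.1-fold lower number from compound 2 to compound 3 (0.04 log units; within the scatter) in this assay, the only single-place step readable in the series so far. This position on the core of compound 2 therefore carries a group of 4 heavy atoms, all carbon, with a number inside the scatter of that of compound 2. Nothing measured alongside this result accounts for it.

Open, on these data alone, is whether this holds for other groups at the same place, such as an amine or a carboxylic acid, since a single bulky carbon group says nothing about them. Also open, as far as these compounds go, is whether tert-butyl gives a similar step on the core of compound 1.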